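A few compounds are considered here, and "the series" means these few. Any claim that something is new, unique, unknown or untested is made for them only; others in the source may bear on it.

In a functional assay on HL60/MX2 cells (Homo sapiens) for antiproliferative activity, read by MTT assay, with a stated time of 48 h (a lower number here means a stronger inhibitor, a higher number a weaker inhibitor), the compounds share one core and differ in the chain on an aromatic nitrogen. Compound 1 `CN(C)CCn1c(N)c(-c2nc3ccccc3[nH]2)c2nc(C#N)c(C#N)nc21`, with dimethylamino on that chain, gives 3780 nM. Compound 2 `CCCn1c(N)c(-c2nc3ccccc3[nH]2)c2nc(C#N)c(C#N)nc21` reads > 50000 nM, which is a limit and not a number. Compound 3 `N#Cc1nc2c(-c3nc4ccccc4[nH]3)c(N)n(CCCO)c2nc1C#N` reads > 50000 nM, also a limit and not a number.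

Compound 4 `N#Cc1nc2c(-c3nc4ccccc4[nH]3)c(N)n(CCCN3CCCCC3)c2nc1C#N` differs from compound 3 by piperidin-1-yl in place of hydroxy on a saturated chain carbon, three bonds along the chain from an aromatic nitrogen, so that 3-hydroxypropyl becomes 3-(piperidin-1-yl)propyl. For the measured compounds named here, two measured steps bear on this change: an at least 13-fold higher number from compound 1 to compound 2 (1.12 log units; beyond the scatter) and an at least 13-fold higher number from compound 1 to compound 3 (1.12 log units; beyond the scatter). Both are large and beyond the scatter, and both replace dimethylamino on the chain. The remaining step, a step that the two limits leave unreadable from compound 2 to compound 3, gives no usable size. Read in reverse, the two large steps point to a large move towards a lower number in this assay, although compound 1 is the only precedent and piperidin-1-yl is not dimethylamino. The expected step is an at least 10-fold lower number from compound 3 to compound 4 (1.00 log units; beyond the scatter). Compound 4 is estimated at 5000 nM, with an expected range of 1500 nM to 20000 nM.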

Compound 4, half-maximal inhibitory concentration: 1010 nM
Beside the measured number, compound 4's estimate is 5.0-fold (0.69 log units) above it; measured number outside the range, below it.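

In this assay, a measurable value on this chain is not tied to dimethylamino alone: piperidin-1-yl in place of hydroxy gives an at least 49-fold lower number from compound 3 to compound 4 (1.69 log units; beyond the scatter), and piperidin-1-yl in place of hydrogen gives an at least 49-fold lower number from compound 2 to compound 4 (1.69 log units; beyond the scatter). The change from the chain of compound 1 to 3-(piperidin-1-yl)propyl gives a 3.7-fold lower number from compound 1 to compound 4 (0.57 log units; beyond the scatter), but it alters the amine and the chain length together, so the two contributions stay unseparated. Compound 2 and compound 3 each stand at a limit and not a number, so their two steps are bounds only: the limit of > 50000 nM in this assay, at which 2 of the 4 values shown sit.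

Still open is whether the lower number follows the piperidine ring or the longer chain, as neither 3-(dimethylamino)propyl nor 2-(piperidin-1-yl)ethyl is among the compounds shown. Also open, going by these compounds, is how a morpholin-4-yl group or a carboxylic acid at the same chain end would read in this assay.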